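The compounds below may be only part of what the source reports. "The series", "measured", "known", "first", "only" and "open" are said of these compounds alone.

The measured compounds:

Compound 1 `COc1ccc(S(=O)(=O)c2nc3ccccc3nc2Nc2cc(OC)cc(OC)c2)cc1`: 6220 nM
Compound 2 `COc1cc(Nc2nc3ccccc3nc2S(=O)(=O)c2ccc(Br)cc2)cc(OC)c1`: 18200 nM

In a functional assay on PC-3 cells (Homo sapiens) for cytotoxicity, read by MTT assay, with a stated time of 72 h (on this read-out lower numbers stand for stronger inhibition and higher numbers for weaker inhibition), compound 1 gives 6220 nM, while compound 2 gives 18200 nM. Going by the values given here, compound 2 therefore stands at the higher of the two numbers so far, separated from its only neighbour by a 2.9-fold higher number from compound 1 to compound 2 (0.47 log units; beyond the scatter), a step that lies beyond the scatter.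

Compound 3 `O=S(=O)(c1ccc(Br)cc1)c1nc2ccccc2nc1Nc1cccc(O)c1` differs from compound 2 in a single place: 3-hydroxyphenyl in place of 3,5-dimethoxyphenyl on a nitrogen on an aromatic ring. Among the compounds with values here, the one measured step, from compound 1 to compound 2, concerns the group carried by the sulfonyl, not the group on the nitrogen, so it does not bear on this change. Within the data shown here, no measured pair shows what exchanging the aryl on the nitrogen does in this assay, and the expectation therefore rests on compound 2 alone, with no direction that can be argued from the numbers. A step of no particular direction, possibly within the scatter, is expected for a 1.2-fold lower number from compound 2 to compound 3 (0.08 log units; within the scatter). Compound 3 is accordingly estimated at 15000 nM in this assay, with a wide range from 4000 nM to 60000 nM that reflects the absence of any relevant step.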

Compound 3, half-maximal inhibitory concentration: 1700 nM
The estimate for compound 3 lay 8.8-fold (0.95 log units) above the measured number; the measured number lies below the stated range.
By their numbers in this assay, from the lowest: compound 3; then compound 1; then compound 2.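

In this assay, the aryl group on the nitrogen proves to be a sensitive place: with the rest of the molecule unchanged, 3-hydroxyphenyl in place of 3,5-dimethoxyphenyl gives an 11-fold lower number from compound 2 to compound 3 (1.03 log units; beyond the scatter). This step is clearly larger than the only earlier one, a 2.9-fold higher number from compound 1 to compound 2 (0.47 log units; beyond the scatter), which concerned bromo in place of methoxy on an aromatic carbon, so the group on the nitrogen can move the number at least as far as that exchange did. Going by these compounds alone, the new group is smaller, with fewer heavy atoms, and carries 1 hydrogen-bond donor where the old one has 0, but no evidence ties the step to either difference.

The compounds shown leave open whether the gain comes from the hydroxy group itself or from the loss of the two methoxy groups, and a plain phenyl or an aminophenyl on the same nitrogen would speak to that. They also leave open whether 3-hydroxyphenyl gives a step of similar size when methoxy takes the place of bromo, as in compound 1.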